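Dichlorophenyl analogue of compound 1 in the cytotoxicity series

This account rests on a few compounds, and the source may have more. Where it says the series, first, only, none or still open, it means among the compounds named here.

Compound 1 `O=C(Cn1cnc([N+](=O)[O-])n1)N1CCN(c2ccc(Cl)cc2)CC1` carries a 4-chlorophenyl piperazine on the shared core. In an ADME assay on L6 cells (Rattus norvegicus) for cytotoxicity (on this read-out higher numbers stand for weaker inhibition and lower numbers for stronger inhibition), compound 1 gives only a limit, > 285000 nM, not a number. Compound 1 therefore sits at the limit of > 285000 nM in this assay, at which 1 of the 2 values shown sits. Among the compounds with values here, the single numeric value belongs to compound 2 `O=C(CN1CCN(c2ccc(Cl)c(Cl)c2)CC1)N1CCN(c2ccc(Cl)c(Cl)c2)CC1`, which in this assay gives 20200 nM; compound 2 is not a one-point neighbour of compound 1, so the two values show only that one compound is measurable and the other is not.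

Compound 3 `O=C(Cn1cnc([N+](=O)[O-])n1)N1CCN(c2ccc(Cl)c(Cl)c2)CC1` differs from compound 1 by chloro in place of hydrogen on an aromatic carbon, that is, 4-chlorophenyl to 3,4-dichlorophenyl. Within the data shown here, no measured step exists for this change, so in this assay the step is expected to be small, an at least 1.2-fold lower number from compound 1 to compound 3 (0.11 log units; that floor lies within the scatter), at most a modest move towards stronger inhibition and possibly none beyond the scatter. Compound 3 is thus expected to give about 220000 nM, between 70000 nM and 600000 nM, with a fair chance that only a limit is reported again.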

Compound 3, half-maximal inhibitory concentration: 108000 nM
Compound 3: middle estimate off by 2.0-fold (0.31 log units), on the high side, within the range that was stated.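

Chloro in place of hydrogen on this aromatic carbon, ortho to the existing chloro group, is the first change in the series that can be read as a step: an at least 2.6-fold lower number from compound 1 to compound 3 (0.42 log units; beyond the scatter), towards stronger inhibition in this assay. Compound 3 gives 108000 nM, so the 3,4-dichlorophenyl group on this core yields a number rather than a limit. As far as these compounds go, the true size of the step stays open and only its lower bound is known, because the value for compound 1 is a limit and not a number: the limit of > 285000 nM in this assay, at which 1 of the 3 values shown sits.

The compounds shown leave open whether a fluoro or a methoxy group on the same aromatic carbon would shift the number in the same way. Compound 2 differs from compound 3 in more than one place, so it does not settle this.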